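A few compounds are considered here, and "the series" means these few. Any claim that something is new, unique, unknown or untested is made for them only; others in the source may bear on it.

Working notes on the series. In a functional assay on A-375 cells (Homo sapiens) for antiproliferative activity (a higher number here means a weaker inhibitor, a lower number a stronger inhibitor), compound 1 `COCCO/N=C/c1c(N)ncnc1Oc1ccc2[nH]c(C)cc2c1F` gives 233 nM. Compound 2 `CO/N=C/c1c(N)ncnc1Oc1ccc2[nH]ccc2c1` gives 783 nM, and compound 3 `CO/N=C/c1c(N)ncnc1Oc1ccc2[nH]cc(C)c2c1` gives 132 nM. Of these three numbers compound 1 stands second highest: its gap to compound 3 lies within the scatter, its gap to compound 2 beyond it. Among the compounds with values here, the only single-place step so far measured is a 5.9-fold lower number from compound 2 to compound 3 (0.77 log units; beyond the scatter), a methyl in place of hydrogen on an aromatic carbon of the shared core. Within the data shown here, compound 1 and compound 3 differ in more than one place, so their two values give no clean step.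

Compound 4 `CCCCO/N=C/c1c(N)ncnc1Oc1ccc2[nH]c(C)cc2c1F` differs from compound 1 by ethyl in place of methoxy on a saturated chain carbon, two bonds along the chain from an oxygen on an unsaturated carbon. Among the measured compounds shown here, the change sits on the chain hung from the oxygen on the unsaturated carbon, a part of the molecule that no measured step touches. The step from compound 2 to compound 3 concerns the aromatic carbon and does not bear on a chain change. Nothing in the numbers therefore argues for a shift in either direction, and the expectation is a step within the scatter.

Compound 4 is estimated to give 250 nM, with a range from 100 nM to 650 nM. The expected step is a 1.1-fold higher number from compound 1 to compound 4 (0.03 log units; within the scatter).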

Compound 4, half-maximal inhibitory concentration: 446 nM
The estimate for compound 4 lay 1.8-fold (0.25 log units) below the measured number; the range from low to high includes it.
By their numbers in this assay, from the lowest: compounds 3, 1, 4 and 2 (each within the scatter of the next, the first and the last beyond it).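

In this assay, replacing methoxy with ethyl on a saturated chain carbon, two bonds along the chain from an oxygen on an unsaturated carbon, gives a 1.9-fold higher number from compound 1 to compound 4 (0.28 log units; within the scatter). Within the data shown here, this is the first step read on the chain, and it does not separate 2-methoxyethoxy from butoxy in this pair, even though the hydrogen-bond acceptor counted on methoxy is absent from ethyl. The compounds at hand offer no measurement that accounts for the size of this step.

As far as these compounds go, whether the chain stays equally open to other groups remains unresolved: a longer chain such as hexyloxy, a terminal amine or a terminal carboxylic acid could each give a step beyond the scatter, and a single pair cannot speak for them. From the compounds shown here alone, the chain step and a 5.9-fold lower number from compound 2 to compound 3 (0.77 log units; beyond the scatter) were also read on different cores, so it remains open whether the two changes would add up on one core.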